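Ethyl to methyl: working notes on compound 3

The source may hold more compounds than are shown below. What is called first, only, known or untested is meant among the compounds shown, and "the series" means these compounds.

Measured in a functional assay on A2780 cells (Homo sapiens) for antiproliferative activity, read by CellTiter-Glo, with a stated time of 4 days; a higher number here means a weaker inhibitor, a lower number a stronger inhibitor:
- compound 1 `CC(=O)NCc1ncc2cc(COc3ccc(C(=O)NCc4cccnc4)cc3)n(CCC3CCCCC3)c2n1`: 15 nM
- compound 2 `CC[C@H](NC(=O)c1ccccc1)c1ccc(NC(=O)[C@H]2C[C@@H]2c2cccnc2)cc1`: 43 nM

Compound 2 holds the higher of the two numbers, and its gap to compound 1 lies beyond the scatter. The two structures differ in many places, so this gap says little about the next change.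

Compound 3 `C[C@H](NC(=O)c1ccccc1)c1ccc(NC(=O)[C@H]2C[C@@H]2c2cccnc2)cc1` carries hydrogen in place of methyl on a saturated chain carbon, two bonds along the chain from an amide-type nitrogen and an aromatic carbon. Cut one bond further out, this reads ethyl to methyl. Among the measured compounds shown here, no measured pair shows this change, so the expectation starts from compound 2 at 43 nM. No step beyond the scatter is expected in this assay, and no direction is favoured. The expected step is a 1.1-fold lower number from compound 2 to compound 3 (0.03 log units; within the scatter). For compound 3 the estimated value is 40 nM, with an expected range of 15 nM to 110 nM.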

Compound 3, half-maximal inhibitory concentration: 1 nM
Beside the measured number, compound 3's estimate is 40-fold (1.60 log units) above it; the whole stated range lies above it.
By their numbers in this assay, from the lowest: compound 3; then compound 1; then compound 2.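

In this assay, the change from ethyl to methyl on the saturated chain carbon gives a 43-fold lower number from compound 2 to compound 3 (1.63 log units; beyond the scatter) and shows that this position is highly sensitive to a change of one carbon, which the earlier comparison of two structures differing in many places could not reveal. The change adds or removes no ring, hydrogen-bond donor, hydrogen-bond acceptor or net charge, yet the step lies far beyond the scatter. Nothing available accounts for the size of this step.

The compounds shown hold only ethyl and methyl at this carbon, so it remains open how a propyl chain, a hydroxymethyl group or a plain methylene carbon bearing no chain would compare. This single pair also leaves open whether the same change would have a step of similar size on the core of compound 1.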